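A few compounds are considered here, and "the series" means these few. Any claim that something is new, unique, unknown or untested is made for them only; others in the source may bear on it.

Compound 1, `O=C(Nc1cccc(Cl)c1)c1cccc(Br)c1`, was tested in an assay for inhibition of HSP60/HSP10 (Homo sapiens), with a stated time of 60 min; on this read-out higher numbers stand for weaker inhibition and lower numbers for stronger inhibition. In this assay compound 1 gives only a limit of the assay, > 100000 nM. Compound 3, `O=C(Nc1ccc(Sc2nc3ccccc3s2)cc1)c1cccc(Br)c1`, carries the same bromo-substituted half of the amide but a different core on the other side; the difference between the two cores is not broken down here. In this assay compound 3 likewise gives only a limit, > 100000 nM. Compound 2, `O=C(Nc1ccc(Sc2nc3ccccc3s2)cc1)c1cccc(Br)c1O`, differs from compound 3 by hydroxy in place of hydrogen on an aromatic carbon. In this assay compound 2 gives 26000 nM. That change made a step of an at least 3.8-fold lower number from compound 3 to compound 2 (0.58 log units; beyond the scatter), and its size is known only as a bound because of the limit of > 100000 nM in this assay, at which 2 of the 3 values shown sit.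

Compound 4, `O=C(Nc1cccc(Cl)c1)c1cc(Br)ccc1O`, is not yet measured. It differs from compound 1 by hydroxy in place of hydrogen on an aromatic carbon. Among the measured compounds shown here, this is the same kind of change as the one from compound 3 to compound 2, but not the same: in compound 2 the entering hydroxy sits ortho to a bromo group, whereas in compound 4 it sits para to a bromo group, in both cases ortho to a large group. Resting on the step from compound 3 to compound 2, a step of an at least 2.0-fold lower number from compound 1 to compound 4 (0.30 log units; that floor lies within the scatter) is expected for compound 4. The starting value of compound 1 is a limit rather than a number, so the footing is uncertain and a limit may be reported again. The estimate for compound 4 in this assay is 50000 nM, expected to lie between 15000 nM and 150000 nM.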

Compound 4, half-maximal inhibitory concentration: > 100000 nM
Compound 4: no number, only a limit; the forecaster's own chance of this, stated with the estimate: 40%; middle value at least 2.0-fold (0.30 log units) from the limit.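

Compound 1 and compound 4 both give only a limit of the assay in this assay, so no step between them can be read: the limit of > 100000 nM in this assay, at which 3 of the 4 values shown sit.

The compounds shown leave open whether hydroxy in place of hydrogen on an aromatic carbon changes the number at all when going from compound 1 to compound 4, and whether its placing para to a bromo group matters.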